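The source may report more compounds than this note shows. Statements on the series, on what has been measured and on what is new or still open speak of the compounds shown alone.

Two compounds of the series have numbers in an assay for inhibition of Neuropeptide Y receptor type 5 (Mus musculus); on this read-out higher numbers stand for weaker inhibition and lower numbers for stronger inhibition. Compound 1 `N#Cc1cccc(Nc2ncc(C(=O)c3ccccc3F)s2)c1` gives 19 nM. Compound 2 `Cc1ccccc1C(=O)c1cnc(Nc2cccc(C#N)c2)s1` gives 4.2 nM, the lowest of the two numbers, with compound 1 as its nearest neighbour. Within the data shown here, the only step measured so far is a 4.5-fold lower number from compound 1 to compound 2 (0.66 log units; beyond the scatter), a change of one substituent.

Compound 3 `Cc1cc(C(=O)c2cnc(Nc3cccc(C#N)c3)s2)c(C)s1` differs from compound 2 by 2,5-dimethylthiophen-3-yl in place of 2-methylphenyl on a carbonyl carbon. Among the measured compounds shown here, the measured step, a 4.5-fold lower number from compound 1 to compound 2 (0.66 log units; beyond the scatter), does not bear on this change directly: it exchanged substituents while leaving the ring in place, and no measured pair shows the exchange of the ring itself. The change is therefore uncovered, and the direction of its effect cannot be read from the numbers shown. For the measured compounds named here, with no step in evidence, the expected step in this assay is a 1.4-fold higher number from compound 2 to compound 3 (0.15 log units; within the scatter), none beyond the scatter, with a wide range to allow for either direction. Compound 3 is accordingly estimated at 6 nM, expected between 1.5 nM and 25 nM.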

Compound 3, half-maximal inhibitory concentration: 14 nM
Compound 3: the middle estimate sits 2.3-fold (0.37 log units) below what was measured, and the stated range covers the measured number.
By their numbers in this assay, from the lowest: compound 2; then compounds 3 and 1 (each within the scatter of the next).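

Among these compounds, the carbonyl carbon also tolerates exchange of the whole ring, not just of a substituent on it, but the exchange has a cost relative to the best compound so far: in this assay the replacement of 2-methylphenyl by 2,5-dimethylthiophen-3-yl gives a 3.3-fold higher number from compound 2 to compound 3 (0.52 log units; beyond the scatter). Against 2-fluorophenyl, the same ring gives a 1.4-fold lower number from compound 1 to compound 3 (0.13 log units; within the scatter), so compound 3 and compound 1 are not separated in this assay, and only the 2-methylphenyl group of compound 2 stands apart. Nothing available here accounts for either step.

The compounds shown leave open how a methoxy group or a chlorine on the phenyl ring would compare with methyl and fluoro, and whether an unsubstituted thiophen-3-yl would match its dimethyl counterpart. Going by these compounds, all three compounds also share the nitrile, so the effect of a carboxylic acid in its place remains open.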